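This account rests on a few compounds, and the source may have more. Where it says the series, first, only, none or still open, it means among the compounds named here.

Measured so far:
compound 1 `CC(C)n1ncnc1-c1ccccc1NCC1=NCCN1` — 104%
compound 2 `Cn1cccc1-c1ccccc1NCC1=NCCN1` — 103%
compound 3 `CCCCn1ncnc1-c1ccccc1NCC1=NCCN1` — 86%

In a functional assay with Alpha-1A adrenergic receptor (Homo sapiens) as the target, read by calcium flux (a higher number here means a larger maximal response, a lower number a smaller maximal response), compound 3 gives the lowest of the three numbers. Its nearest neighbour is compound 2, which gives 103% in this assay, a gap beyond the scatter; compound 1 gives 104%, also beyond the scatter. Compound 1 and compound 2 lie within the scatter of each other.

Compound 4 `Cn1ncnc1-c1ccccc1NCC1=NCCN1` differs from compound 3 in one place: hydrogen in place of propyl on a saturated chain carbon bound to an aromatic nitrogen.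

Going by the values given here, the one step that bears on this change is the one from compound 1 to compound 3, a number 18 percentage points lower from compound 1 to compound 3 (beyond the scatter), where the group on the aromatic nitrogen was enlarged from isopropyl to butyl. Compound 4 moves the other way, from butyl to methyl. Compound 2 also carries a methyl on an aromatic nitrogen, though on a different core, and gives 103%. A return toward the higher numbers of compound 1 and compound 2 is therefore expected, by a step of about a number 14 percentage points higher from compound 3 to compound 4 (beyond the scatter) in this assay. Compound 4 is estimated at 100%, within 85% to 115%.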

Compound 4, largest response reached (reported as maximal response), in percent of the reference or control that the assay uses: 91%
Compound 4: the middle estimate sits 9 percentage points above what was measured, and the stated range covers the measured number.
By their numbers in this assay, from the lowest: compounds 3 and 4 (each within the scatter of the next); then compounds 2 and 1 (each within the scatter of the next).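

With the shared core held fixed in this assay, butyl to methyl on the aromatic nitrogen gives a number 5 percentage points higher from compound 3 to compound 4 (within the scatter) and so does not separate the two groups, which removes the simple reading that the response follows chain length. Isopropyl now stands apart from methyl as well as from butyl, with a number 13 percentage points lower from compound 1 to compound 4 (beyond the scatter) alongside a number 18 percentage points lower from compound 1 to compound 3 (beyond the scatter) and both beyond the scatter. The ring also matters with an N-methyl group on both sides, since 1-methyl-1H-1,2,4-triazol-5-yl in place of 1-methyl-1H-pyrrol-2-yl gives a number 12 percentage points lower from compound 2 to compound 4 (beyond the scatter) and this too lies beyond the scatter.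

An ethyl, a cyclopropyl or a tert-butyl group on the same nitrogen would show whether branching, rather than isopropyl alone, goes with the higher number. No measured evidence is available to explain any of these steps.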